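From 2,4,6-trihydroxyphenyl to 2,4-difluorophenyl on a shared core

The source may hold more compounds than are shown below. What is called first, only, known or untested is meant among the compounds shown, and "the series" means these compounds.

Within the data shown here, in a functional assay on DU-145 cells (Homo sapiens) for inhibition, read by trypan blue exclusion, with a stated time of 96 h (a higher number here means a weaker inhibitor of growth, a lower number a stronger inhibitor of growth), compound 2 `O=C(/C(=C\c1c(O)cc(O)cc1O)Sc1ccc(Br)cc1)c1ccc(Cl)cc1` gives 50000 nM and stands level with compound 1 `Cc1ccc(CS/C(=C/c2c(O)cc(O)cc2O)C(=O)c2ccc(Cl)cc2)cc1` at 50000 nM on the numbers so far. Among the measured compounds shown here, compound 3 `O=C(/C(=C\c1ccc(F)cc1F)Sc1ccc(Br)cc1)c1ccc(Cl)cc1` brings 2,4-difluorophenyl in place of 2,4,6-trihydroxyphenyl on a double-bonded chain carbon bound to a double-bonded chain carbon as its one change: 2,4-difluorophenyl in place of 2,4,6-trihydroxyphenyl on a double-bonded chain carbon bound to a double-bonded chain carbon. For the measured compounds named here, the only measured step, no change at the digits printed from compound 1 to compound 2 (within the scatter) on a sulfur, does not touch this place, so the data offer no direct guide. A modest gain is expected, given as a 2.0-fold lower number from compound 2 to compound 3 (0.30 log units; within the scatter) in this assay with no change still possible. For compound 3 the estimate is 25000 nM with 4000 nM to 60000 nM as its expected range.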

Compound 3, concentration for 50% growth inhibition: 1000 nM
Compound 3: the middle estimate sits 25-fold (1.40 log units) above what was measured; measured number below the stated range.
By their numbers in this assay, from the lowest: compound 3; then compounds 1 and 2 (each within the scatter of the next).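

In this assay the group on a double-bonded chain carbon bound to a double-bonded chain carbon proves a sensitive place: 2,4-difluorophenyl in place of 2,4,6-trihydroxyphenyl gives a 50-fold lower number from compound 2 to compound 3 (1.70 log units; beyond the scatter), whereas the change on sulfur gave no change at the digits printed from compound 1 to compound 2 (within the scatter). The entering group has no hydrogen-bond donors or acceptors by count, unlike the group that leaves. Nothing at hand explains the gain.

Still open, from the compounds shown here alone, is whether hydroxyl loss or fluorine entry carries the step, which plain phenyl or 2,4-dichlorophenyl at this place could help separate. Going by these compounds, whether the gain persists with 4-methylbenzyl on the sulfur also remains open.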